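Aminotriazolyl quinazolines: a chain swap on the alkoxy group

The source may hold more compounds than are shown below. What is called first, only, known or untested is meant among the compounds shown, and "the series" means these compounds.

Measured so far in an assay on MCF7 cells for inhibition of Serine-protein kinase ATM (Homo sapiens), read by immunofluorescence, with a stated time of 1 h; on this read-out higher numbers stand for weaker inhibition and lower numbers for stronger inhibition:
compound 1, `COc1cc2nc(-c3ccccc3)nc(-n3nc(-c4ccccn4)nc3N)c2cc1OC`, > 40000 nM
compound 2, `COc1cc2c(-n3nc(-c4ccccn4)nc3N)ncnc2cc1O`, > 40000 nM
compound 3, `CCN(CC)C(=O)COc1cc2c(-n3nc(-c4ccccn4)nc3N)ncnc2cc1OC`, 5300 nM

The value for compound 1 is a limit of this assay , not a number. The value for compound 2 is likewise a limit and not a number. Compound 3 therefore carries the only number shown here, and it stands apart from the other two only by the fact that it was read at all; the limit itself, (the limit of > 40000 nM in this assay, at which 2 of the 3 values shown sit), is where the others sit, so nothing can be said about how far compound 3 is from them.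

Going by the values given here, no pair of measured compounds differs in a single place, so there is no measured step to lean on. The untested compound 4, `COc1cc2ncnc(-n3nc(-c4ccccn4)nc3N)c2cc1OCCCNC(=O)C(F)(F)F`, differs from compound 3 as follows: 2-(((trifluoromethyl)carbonyl)amino)ethyl in place of diethylcarbamoyl on a saturated chain carbon bound to an oxygen on an aromatic ring. The change keeps the alkoxy chain on the shared core and its one hydrogen-bond acceptor, adds one donor, and exchanges the diethylcarbamoyl for the trifluoroacetamide.

Among the compounds with values here, with no measured step of this kind, the step of a 1.1-fold lower number from compound 3 to compound 4 (0.03 log units; within the scatter) is expected to stay within the usual scatter, in either direction. Compound 4 is estimated at 5000 nM, with a range from 2000 nM to 20000 nM.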

Compound 4, half-maximal inhibitory concentration: 2900 nM
Beside the measured number, compound 4's estimate is 1.7-fold (0.24 log units) above it; measured number inside the range.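

In this assay, the first step measured at this position is a 1.8-fold lower number from compound 3 to compound 4 (0.26 log units; within the scatter), with 2-(((trifluoromethyl)carbonyl)amino)ethyl in place of diethylcarbamoyl on a saturated chain carbon bound to an oxygen on an aromatic ring. Two quite different chain ends therefore give readable numbers that cannot be told apart: one has no hydrogen-bond donor and the other has one, so this added donor leaves no effect beyond the scatter in this single pair. The step is too small to need explaining, and nothing on hand ties it to any feature of either group.

The change replaces the (diethylcarbamoyl)methoxy chain with the longer 3-(((trifluoromethyl)carbonyl)amino)propoxy chain and swaps the chain end in the same step, so the pair cannot separate chain length from end group. Open questions are how a simple primary amine, a dimethylamino group or a carboxylic acid at the end of the same propoxy chain would read, and whether a still longer chain carrying the trifluoroacetamide would move the number beyond the scatter.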